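Swapping Nitro for Fluoro on a Receptor Agonist

The source may report more compounds than this note shows. Statements on the series, on what has been measured and on what is new or still open speak of the compounds shown alone.

Of the compounds shown here, two built on one shared core have been measured so far. Compound 1 `CCCCCNc1oc2c(C)ncc(CO)c2c1Nc1ccccn1` gives 5810 nM in a functional assay on HEK293 cells for agonist activity at Toll-like receptor 8 (Homo sapiens), read by reporter gene assay; on this read-out higher numbers stand for an effect only at larger amounts of compound and lower numbers for an effect already at smaller amounts. For the measured compounds named here, compound 2 `CCCCCNc1oc2c(C)ncc(CO)c2c1Nc1cccc([N+](=O)[O-])c1` gives 850 nM in this assay, the lowest of the two numbers known; the single step on record, a 6.8-fold lower number from compound 1 to compound 2 (0.83 log units; beyond the scatter), shows that exchanging the ring on the nitrogen attached to the core can move the read-out well beyond the scatter.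

Compound 3 `CCCCCNc1oc2c(C)ncc(CO)c2c1Nc1cccc(F)c1` differs from compound 2 by fluoro in place of nitro on an aromatic carbon. Going by the values given here, no measured step bears directly on this exchange: the step of a 6.8-fold lower number from compound 1 to compound 2 (0.83 log units; beyond the scatter) replaces a whole ring rather than a single group on it, so it only tells that this part of the molecule matters, not in which direction a smaller change will go. With the nitro group, two hydrogen-bond acceptors leave and nothing of that kind enters. The step of a 2.4-fold higher number from compound 2 to compound 3 (0.37 log units; beyond the scatter) is therefore expected to point toward a higher number, with wide uncertainty. Compound 3 is estimated at 2000 nM in this assay, within a range from 500 nM to 8000 nM.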

Compound 3, half-maximal effective concentration: 370 nM
The estimate for compound 3 lay 5.4-fold (0.73 log units) above the measured number, outside the stated range (below it).
By their numbers in this assay, from the lowest: compound 3; then compound 2; then compound 1.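

Fluoro in place of nitro on this aromatic carbon gives a 2.3-fold lower number from compound 2 to compound 3 (0.36 log units; beyond the scatter) in this assay, so within this pair the number does not depend on keeping the hydrogen-bond acceptors counted on the nitro group. The earlier step replaced a whole ring, whereas this one changes a single group on the ring and shows that such an exchange alone can move the number beyond the scatter. Measured against the pyridin-2-yl ring, the 3-fluorophenyl ring gives a 16-fold lower number from compound 1 to compound 3 (1.20 log units; beyond the scatter), a large step that shows how much the choice of ring on this nitrogen can matter, while no measurement available here explains why fluoro gives the lower number.

The compounds shown cannot say whether the number depends on having any group at this place, since a plain phenyl ring carrying only hydrogen is not among them. They also leave open how an amine, a methoxy group or a carboxylic acid at this same place would compare with fluoro and nitro, so two groups on one ring are too few to define a trend.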